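The source may report more compounds than this note shows. Statements on the series, on what has been measured and on what is new or still open speak of the compounds shown alone.

Of the compounds shown here, three built on one shared core have been measured in a functional assay on SK-MEL-28 cells (Homo sapiens) for antiproliferative activity, read by sulforhodamine B assay, with a stated time of 48 h; a lower number here means a stronger inhibitor, a higher number a weaker inhibitor. Compound 1 `Nc1cccc2c(-c3cccc(NC(=O)c4ccc(Cl)c(C(F)(F)F)c4)c3)ccnc12` gives 2900 nM. Compound 2 `CC(=O)Nc1cccc2c(-c3cccc(NC(=O)c4ccc(Cl)c(C(F)(F)F)c4)c3)ccnc12`, which carries an acetyl instead of a hydrogen on a nitrogen on an aromatic ring, gives 3500 nM; the step of a 1.2-fold higher number from compound 1 to compound 2 (0.08 log units; within the scatter) is within the scatter. Compound 3 `Nc1cccc2c(-c3cccc(NC(=O)Nc4cc(C(F)(F)F)cc(C(F)(F)F)c4)c3)ccnc12` gives 2100 nM, the lowest of the three numbers, yet its gaps to compound 1 and to compound 2 both fall within the scatter, so none of the three can be called stronger or weaker than another.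

Compound 4 `CC(=O)Nc1cccc2c(-c3cccc(NC(=O)Nc4cc(C(F)(F)F)cc(C(F)(F)F)c4)c3)ccnc12` has not yet been measured. It differs from compound 3 in one place: acetyl in place of hydrogen on a nitrogen on an aromatic ring. Within the data shown here, this is the same exchange that turns compound 1 into compound 2, so that single step is the only direct guide here. Because that step a 1.2-fold higher number from compound 1 to compound 2 (0.08 log units; within the scatter) stayed within the scatter, no change beyond the scatter is expected for compound 4 in this assay either. Compound 4 is therefore estimated at 2500 nM, with a range from 1200 nM to 5500 nM. The expected step of a 1.2-fold higher number from compound 3 to compound 4 (0.08 log units; within the scatter) is small, leaning toward a slightly higher number.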

Compound 4, half-maximal inhibitory concentration: 23400 nM
The estimate for compound 4 lay 9.4-fold (0.97 log units) below the measured number, outside the stated range (above it).
By their numbers in this assay, from the lowest: compounds 3, 1 and 2 (each within the scatter of the next); then compound 4.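

In this assay, the amino to acetamido change is not harmless at this nitrogen, as the earlier pair suggested: it gives an 11-fold higher number from compound 3 to compound 4 (1.05 log units; beyond the scatter). Compound 4 is clearly a weaker inhibitor than compound 3, so a hydrogen on this nitrogen can matter a great deal, even though the same exchange made no readable difference between compound 1 and compound 2. The effect of the acetyl therefore depends on the rest of the molecule, and a step read on one core cannot simply be carried over to another: the same change on two cores in this assay, a 1.2-fold higher number (0.08 log units; within the scatter) from compound 1 to compound 2 and an 11-fold higher number (1.05 log units; beyond the scatter) from compound 3 to compound 4, 9.2-fold (0.97 log units) apart, beyond the scatter of two such steps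

Compounds 3 and 4 carry a urea and two trifluoromethyl groups, where compounds 1 and 2 carry an amide with a chloro and a single trifluoromethyl group, so the compounds shown cannot tell which of these features makes the acetyl step large on one core and small on the other. As far as these compounds go, it also remains open how a smaller or longer group on this nitrogen, such as a methyl or a propanoyl, would behave on either core.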